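Swapping an Ester for a Fluorinated Ring

The compounds below may be only part of what the source reports. "The series", "measured", "known", "first", "only" and "open" are said of these compounds alone.

Compound 1 `COc1ccc(Cc2c(C)[nH]n(-c3nc4ccccc4[nH]3)c2=O)cc1` and compound 2 `COC(=O)Cc1c(C)[nH]n(-c2nc3ccccc3[nH]2)c1=O` share one core and differ at a single spot. For the measured compounds named here, in an assay on isolated protein for inhibition of alpha-ketoglutarate-dependent dioxygenase alkB homolog 3 (Homo sapiens), read by polymerase chain reaction, with a stated time of 1 h (on this read-out lower numbers stand for stronger inhibition and higher numbers for weaker inhibition), compound 1 gives 630 nM, while compound 2 gives 4300 nM, the highest of the two numbers seen so far; the one measured step, a 6.8-fold higher number from compound 1 to compound 2 (0.83 log units; beyond the scatter), separates the pair. Compound 3 `Cc1[nH]n(-c2nc3ccccc3[nH]2)c(=O)c1Cc1ccc(F)cc1` carries 4-fluorophenyl in place of methoxycarbonyl on a saturated chain carbon bound to an aromatic carbon. That earlier step exchanged an aromatic ring for the ester and weakened inhibition, so putting an aromatic ring back is expected to reverse much of it. Compound 3 is therefore expected near 800 nM, between 300 nM and 2500 nM, an expected step of a 5.4-fold lower number from compound 2 to compound 3 (0.73 log units; beyond the scatter).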

Compound 3, half-maximal inhibitory concentration: 600 nM
Compound 3: the middle estimate sits 1.3-fold (0.12 log units) above what was measured; low and high end bracket the measured number.
By their numbers in this assay, from the lowest: compounds 3 and 1 (each within the scatter of the next); then compound 2.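

Putting 4-fluorophenyl in place of methoxycarbonyl gives a 7.2-fold lower number from compound 2 to compound 3 (0.86 log units; beyond the scatter) in this assay, so a second aromatic ring at this position outdoes the ester with more than one ring substituent. Fluoro in place of methoxy on an aromatic carbon gives a 1.1-fold lower number from compound 1 to compound 3 (0.02 log units; within the scatter), so this assay does not separate those two ring substituents. No evidence at hand explains the difference between ring and ester. Still open, as far as these compounds go, is how a plain benzyl, a ring carrying an amine, or a carboxylic acid would read at this position.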